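Methyl in Place of Hydrogen on a Shared Core

The source may hold more compounds than are shown below. What is called first, only, known or untested is meant among the compounds shown, and "the series" means these compounds.

Of the compounds shown here, three of one series have been tested in a functional assay on the whole organism for positive allosteric modulation, with Rattus norvegicus as the target; on this read-out higher numbers stand for an effect only at larger amounts of compound and lower numbers for an effect already at smaller amounts. Compound 1 `Cc1nn(C)c2c1C(c1cccc(F)c1)=NCCN2` gives 2.5 mg/kg. Compound 2 `CCc1nn(C)c2c1C(c1cccc(F)c1)=NCCN2` gives 2.5 mg/kg. Compound 3 `Cc1cccc(C2=NCCNc3c2c(C)nn3C)c1` gives 2.5 mg/kg. The change from compound 1 to compound 2 is methyl in place of hydrogen on a saturated chain carbon bound to an aromatic carbon, and no change at the digits printed from compound 1 to compound 2 (within the scatter). The two cores differ by methyl in place of fluoro on an aromatic carbon; here too no change at the digits printed from compound 1 to compound 3 (within the scatter).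

Compound 4 `CCc1nn(C)c2c1C(c1cccc(C)c1)=NCCN2` has not yet been measured in this assay. Within the data shown here, it differs from compound 3 by methyl in place of hydrogen on a saturated chain carbon bound to an aromatic carbon, the same change as the one from compound 1 to compound 2, made at the same place on the other core. Because no change at the digits printed from compound 1 to compound 2 (within the scatter) on the core of compound 1, the expectation is that no change at the digits printed from compound 3 to compound 4 (within the scatter) on the core of compound 3, with the scatter of the method being the only source of deviation foreseen. Compound 4 is therefore estimated to give 2.5 mg/kg in this assay, with a likely range from 1.2 mg/kg to 5 mg/kg.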

Compound 4, minimum effective dose: 5 mg/kg
For compound 4 the middle estimate is 2.0-fold (0.30 log units) below the measured one, and the stated range covers the measured number.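

In this assay, methyl in place of hydrogen on a saturated chain carbon bound to an aromatic carbon now reads as a 2.0-fold higher number from compound 3 to compound 4 (0.30 log units; within the scatter), and set beside its earlier counterpart, the change carries from one core to the other as far as this read-out can tell: the same change on two cores in this assay, no change at the digits printed (within the scatter) from compound 1 to compound 2 and a 2.0-fold higher number (0.30 log units; within the scatter) from compound 3 to compound 4, 2.0-fold (0.30 log units) apart, within the scatter of two such steps Methyl in place of fluoro on an aromatic carbon, now read on the ethyl-bearing pair, gives a 2.0-fold higher number from compound 2 to compound 4 (0.30 log units; within the scatter), and it too agrees with the step already seen: the same change on two cores in this assay, no change at the digits printed (within the scatter) from compound 1 to compound 3 and a 2.0-fold higher number (0.30 log units; within the scatter) from compound 2 to compound 4, 2.0-fold (0.30 log units) apart, within the scatter of two such steps This does not show that either change is without effect or that the steps on the two cores are identical, only that any difference between them cannot be told from the scatter in these four compounds.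

The compounds shown leave open how a longer chain such as propyl, or an amine on that saturated chain carbon, would behave. They also leave open whether chloro or methoxy on the aromatic carbon would fit the same picture.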